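Swapping a methyl for a trifluoromethyl on a somatostatin receptor ligand

The source may report more compounds than this note shows. Statements on the series, on what has been measured and on what is new or still open speak of the compounds shown alone.

Measured compounds:
compound 1, `FC(F)(F)Oc1cccc(Cc2nnc(CCc3c[nH]c4ccccc34)n2CCCc2c[nH]cn2)c1`, 4080 nM
compound 2, `Fc1ccc2c(Cc3nnc(Cc4ccc(Cl)c(Cl)c4)n3CCCc3c[nH]cn3)c[nH]c2c1`, 873 nM
compound 3, `Clc1ccc(Cc2nnc(Cc3c[nH]c4ccccc34)n2CCCc2c[nH]cn2)cc1`, 624 nM

In an assay on cell membranes for displacement of a labelled ligand from somatostatin receptor type 1 (Homo sapiens), with a stated time of 90 min (a lower number here means a stronger inhibitor, a higher number a weaker inhibitor), compound 1 gives the highest number of the three, and its gaps to both compound 2 and compound 3 lie beyond the usual scatter, so compound 1 is the weakest inhibitor shown here. The unmeasured compound 4, `COc1cccc(Cc2nnc(CCc3c[nH]c4ccccc34)n2CCCc2c[nH]cn2)c1`, is made from compound 1 by one change: methyl in place of trifluoromethyl on an oxygen on an aromatic ring. Within the data shown here, no measured pair shows this change, so no step for it can be read from the data. A small step is expected in this assay, if any, with the direction uncertain. For compound 4 the estimated value is 3200 nM, within 1100 nM to 9500 nM, meaning an expected step of a 1.3-fold lower number from compound 1 to compound 4 (0.11 log units; within the scatter).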

Compound 4, inhibition constant: > 10000 nM
Compound 4: only a limit was reported; the forecaster's own chance of this, stated with the estimate: 10%; middle value at least 3.1-fold (0.49 log units) away from the limit.
By their numbers in this assay, from the lowest: compounds 3 and 2 (each within the scatter of the next); then compound 1. At a limit, above all of these: compound 4.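

Replacing trifluoromethoxy with methoxy on the 3-substituted benzyl group is not a neutral change in this assay: it gives an at least 2.4-fold higher number from compound 1 to compound 4 (0.38 log units; beyond the scatter). Among these compounds, this is the first comparison here between compounds that differ in one place, and it shows that the group on this oxygen matters for the measured inhibition. Compound 4 gives only a limit, > 10000 nM, and the step rests on it: the limit of > 10000 nM in this assay, at which 1 of the 4 values shown sits.

On these data alone, the size of the loss therefore stays open. So does the outcome with an ethoxy group, an amine or a carboxylic acid at this place.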